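Swapping the phenyl substituent on the triazole of compound 1

The compounds below may be only part of what the source reports. "The series", "measured", "known", "first", "only" and "open" are said of these compounds alone.

Measured compounds:
Compound 1, `CC1(C)[C@H]2CC[C@]1(C)N(Cc1cn(-c3cccc(Cl)c3)nn1)C(=O)C2`, in a functional assay on A549 cells (Homo sapiens) for inhibition, read by MTT assay, with a stated time of 24 h (on this read-out higher numbers stand for weaker inhibition and lower numbers for stronger inhibition), gives 60 nM.
Compound 2, `CC1(C)[C@H]2CC[C@]1(C)N(Cc1cn(-c3ccc(O)cc3)nn1)C(=O)C2`, in this assay gives 140 nM.
Compound 3, `CC1(C)[C@H]2CC[C@]1(C)N(Cc1cn(-c3ccccc3O)nn1)C(=O)C2`, in this assay gives 230 nM.

Compound 1 has the lowest number of the three, and both other compounds stand beyond the scatter from it. Moving to compound 2 is a step of a 2.3-fold higher number from compound 1 to compound 2 (0.37 log units; beyond the scatter), and moving to compound 3 a step of a 3.8-fold higher number from compound 1 to compound 3 (0.58 log units; beyond the scatter). Between compound 2 and compound 3 the step is a 1.6-fold higher number from compound 2 to compound 3 (0.22 log units; within the scatter), so those two cannot be told apart.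

Compound 4, `COc1ccc(-n2cc(CN3C(=O)C[C@@H]4CC[C@@]3(C)C4(C)C)nn2)cc1`, differs from compound 1 in one place: 4-methoxyphenyl in place of 3-chlorophenyl on an aromatic nitrogen. The measured steps that bear on this are the two in which the 3-chlorophenyl group of compound 1 was exchanged for another ring on the same aromatic nitrogen. Both exchanges gave modestly higher numbers, by a 2.3-fold higher number from compound 1 to compound 2 (0.37 log units; beyond the scatter) and a 3.8-fold higher number from compound 1 to compound 3 (0.58 log units; beyond the scatter). The closest comparison is compound 2, since 4-methoxyphenyl and 4-hydroxyphenyl both place a single oxygen substituent at the same ring position. A modest weakening is therefore expected, of about a 2.0-fold higher number from compound 1 to compound 4 (0.30 log units; within the scatter).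

Compound 4 is estimated at 120 nM in this assay, within a range of 60 nM to 260 nM.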

Compound 4, half-maximal inhibitory concentration: 50 nM
The estimate for compound 4 lay 2.4-fold (0.38 log units) above the measured number; measured number below the stated range.
By their numbers in this assay, from the lowest: compounds 4 and 1 (each within the scatter of the next); then compounds 2 and 3 (each within the scatter of the next).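

In this assay, the 3-chlorophenyl group can give way to 4-methoxyphenyl on this aromatic nitrogen with no change that stands beyond the scatter (a 1.2-fold lower number from compound 1 to compound 4 (0.08 log units; within the scatter)), whereas the earlier exchanges had only raised the number. The sharper lesson comes from the oxygen substituent itself: placing a methyl on the oxygen of compound 2 gives a clear drop (a 2.8-fold lower number from compound 2 to compound 4 (0.45 log units; beyond the scatter)), and compound 4 also lies well below the other hydroxyphenyl analogue (a 4.6-fold lower number from compound 3 to compound 4 (0.66 log units; beyond the scatter)), so the higher numbers of compounds 2 and 3 go with a free hydroxyl on the ring and not simply with the loss of 3-chlorophenyl. No measurement shown here explains why capping that oxygen has this effect.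

Going by these compounds, it remains open whether the methyl on the oxygen could be extended to a longer chain, such as ethyl or butyl, without moving the number. The compounds shown also leave unanswered how the ring would fare carrying an amine or a carboxylic acid in place of the methoxy group.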